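Sulfonyl aryl exchange in a weakly antiproliferative hydrazide series

This account rests on a few compounds, and the source may have more. Where it says the series, first, only, none or still open, it means among the compounds named here.

Compound 1 `CC(=O)Nc1ccc(S(=O)(=O)NNC(=O)c2cccnc2Nc2ccc(Cl)cc2)cc1` has been tested in a functional assay on A498 cells (Homo sapiens) for antiproliferative activity; a higher number here means that more compound is tolerated, a lower number that less compound is tolerated. In this assay compound 1 gives only a limit, > 100000 nM, which marks the edge of what the assay reports and not a number. Where compound 1 stands is therefore known only through (the limit of > 100000 nM in this assay, at which 1 of the 2 values shown sits). Compound 2 `O=C(NNS(=O)(=O)c1ccc(F)cc1)c1cccnc1Nc1ccc(Cl)cc1Cl`, with 4-fluorophenyl on the sulfonyl sulfur and 2,4-dichlorophenyl on the amino nitrogen, gives in this assay 77600 nM. Among the compounds with values here, no pair of measured compounds differs in one place alone, so the two values show nothing beyond the fact that both lie at the high end of the concentration scale.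

Compound 3 `O=C(NNS(=O)(=O)c1ccc(Cl)cc1Cl)c1cccnc1Nc1ccc(Cl)cc1` remains to be measured. It differs from compound 1 by 2,4-dichlorophenyl in place of 4-acetamidophenyl on a sulfonyl sulfur. Within the data shown here, with no single-change step available, the step in this assay is expected to be none beyond the usual scatter, with no preferred direction, and a limit rather than a number remains quite possible. Compound 3 is expected to give 70000 nM, within 25000 nM to 200000 nM. The estimated step from compound 1 to compound 3 is an at least 1.4-fold lower number from compound 1 to compound 3 (0.15 log units; that floor lies within the scatter).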

Compound 3, concentration lethal to 50% of the cells: 91200 nM
Compound 3: middle estimate off by 1.3-fold (0.11 log units), on the low side, and the stated range covers the measured number.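

Within the data shown here, at this sulfonyl sulfur, the first single-place comparison in this assay comes from 2,4-dichlorophenyl in place of 4-acetamidophenyl, and it gives an at least 1.0-fold lower number from compound 1 to compound 3 (0.04 log units; that floor lies within the scatter). For compound 1, the reading of > 100000 nM is a limit of the assay and not a number, so the printed step is only a floor. Among these compounds, the entering group has 0 hydrogen-bond donors and 0 hydrogen-bond acceptors against 1 of each on the leaving group, yet compound 3, now with a true number of 91200 nM, stays at the high end of the concentration scale, so this exchange gives no step at this position that can be read as beyond the scatter.

From the compounds shown here alone, the real size of the step stays open, and with it whether the exchange changes anything at all in this assay: the limit of > 100000 nM in this assay, at which 1 of the 3 values shown sits. Also open, going by these compounds, is whether an amine or a carboxylic acid on the phenyl ring at this sulfonyl sulfur, or a plain methyl in place of that ring, would bring a number clear of the scatter.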